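Acetylation of the hydroxyl in compound 3

The source may hold more compounds than are shown below. What is called first, only, known or untested is meant among the compounds shown, and "the series" means these compounds.

Compound 3 `CCCC(O)CC(=O)O[C@H](CC=C(C)C)C1=CC(=O)c2c(O)ccc(O)c2C1=O` stands at the limit of a functional assay on DU-145 cells (Homo sapiens) for cytotoxicity, read by MTT assay; a lower number here means a stronger inhibitor, a higher number a weaker inhibitor: compound 3 gives > 100000 nM, which is a limit and not a number. Compound 1 `CC(C)=CC[C@@H](OC(=O)c1ccoc1)C1=CC(=O)c2c(O)ccc(O)c2C1=O` also gives a limit, > 100000 nM. For the measured compounds named here, compound 2 `CC[C@@](C)(O)CC(=O)O[C@H](CC=C(C)C)C1=CC(=O)c2c(O)ccc(O)c2C1=O` gives 12700 nM, the only number in the set. The measured steps are an at least 7.8-fold lower number from compound 1 to compound 2 (0.89 log units; beyond the scatter) and an at least 7.8-fold higher number from compound 2 to compound 3 (0.89 log units; beyond the scatter), while a step that the two limits leave unreadable from compound 1 to compound 3; two of the three values sit at the limit of > 100000 nM in this assay, at which 2 of the 3 values shown sit. Compound 4 `CCCC(CC(=O)O[C@H](CC=C(C)C)C1=CC(=O)c2c(O)ccc(O)c2C1=O)OC(C)=O` carries acetyl in place of hydrogen on an oxygen on a saturated carbon. Going by the values given here, no measured step exchanges a hydrogen on such an oxygen for acetyl, so none bears directly on this change, and the starting value is itself a limit. For compound 4 the expected step is an at least 1.2-fold lower number from compound 3 to compound 4 (0.09 log units; that floor lies within the scatter), with a fair chance of another limit. Compound 4 is therefore estimated at 80000 nM, between 15000 nM and 300000 nM.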

Compound 4, half-maximal inhibitory concentration: 55700 nM
Compound 4: middle estimate off by 1.4-fold (0.16 log units), on the high side; low and high end bracket the measured number.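

With acetyl in place of hydrogen on the oxygen, compound 4 gives a readable number in this assay, whereas compound 3 gives only a limit: the limit of > 100000 nM in this assay, at which 2 of the 4 values shown sit. The series shows an at least 1.7-fold lower number from compound 3 to compound 4 (0.25 log units; that floor lies within the scatter) and an at least 1.7-fold lower number from compound 1 to compound 4 (0.25 log units; that floor lies within the scatter), so neither step fixes a true size. Compound 2 still keeps the lower number, with a 4.4-fold higher number from compound 2 to compound 4 (0.64 log units; beyond the scatter).

Open, from the compounds shown here alone, is whether the acetyl itself matters at this oxygen, which a longer acyl such as butyryl or a methyl ether there would test. Also open, going by these compounds, is how acetoxy behaves on the 1-hydroxy-1-methylpropyl chain of compound 2.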